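The source may hold more compounds than are shown below. What is called first, only, known or untested is meant among the compounds shown, and "the series" means these compounds.

Working notes on the series.

Of the compounds shown here, three have been measured so far. Compound 1 `COc1cc2c(Oc3ccc(NC(=O)c4cc(-c5ccccc5F)ccn4)cc3F)ccnc2cc1OCCCN1CCCCC1` and compound 2 `COc1cc2c(Oc3ccc(NC(=O)c4cc(-c5ccccc5F)ccn4)cc3F)ccnc2cc1OCCCN1CCN(C)CC1` share one core; compound 3 `COc1cc2c(Oc3ccc(NC(=O)c4nccc(-c5ccc(C)cc5)n4)cc3F)ccnc2cc1OCCCN1CCCCC1` carries a different core, and how the two cores differ is not broken down here. In a functional assay on HT-29 cells (Homo sapiens) for cytotoxicity, read by MTT assay, with a stated time of 72 h (a lower number here means a stronger inhibitor, a higher number a weaker inhibitor), compound 1 gives 320 nM, compound 2 gives 220 nM and compound 3 gives 620 nM. Compound 3 stands at the highest number of the three; against compound 1 the gap is within the scatter, against compound 2 it is beyond it.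

One change occurs twice in the set. From compound 1 to compound 2 it is 4-methylpiperazin-1-yl in place of piperidin-1-yl on a saturated chain carbon, three bonds along the chain from an oxygen on an aromatic ring, and it gave a 1.5-fold lower number from compound 1 to compound 2 (0.16 log units; within the scatter), a step that is within the scatter.

Compound 4 `COc1cc2c(Oc3ccc(NC(=O)c4nccc(-c5ccc(C)cc5)n4)cc3F)ccnc2cc1OCCCN1CCN(C)CC1` has not been measured. It is made from compound 3 by 4-methylpiperazin-1-yl in place of piperidin-1-yl on a saturated chain carbon, three bonds along the chain from an oxygen on an aromatic ring. Both changes sit on the same saturated chain carbon, three bonds along the chain from an oxygen on an aromatic ring, so this is the same change, made on the core of compound 3 instead of the core of compound 1.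

Within the data shown here, the only guide is the earlier pair. Because that change gave a 1.5-fold lower number from compound 1 to compound 2 (0.16 log units; within the scatter), compound 3 to compound 4 is expected to show a step of about the same size, a 1.5-fold lower number from compound 3 to compound 4 (0.17 log units; within the scatter). Compound 4 is therefore estimated at 420 nM, most likely between 200 nM and 900 nM.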

Compound 4, half-maximal inhibitory concentration: 210 nM
Compound 4: the middle estimate sits 2.0-fold (0.30 log units) above what was measured; the measured number falls inside the stated range.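

Carried to the other core, 4-methylpiperazin-1-yl in place of piperidin-1-yl gave a 3.0-fold lower number from compound 3 to compound 4 (0.47 log units; beyond the scatter) in this assay, a step that lies beyond the scatter, whereas the earlier step on the core of compound 1 did not. Even so, the two steps cannot be told apart, and on these data the change carries across both cores with the number moving the same way and no measurable difference in size: the same change on two cores in this assay, a 1.5-fold lower number (0.16 log units; within the scatter) from compound 1 to compound 2 and a 3.0-fold lower number (0.47 log units; beyond the scatter) from compound 3 to compound 4, 2.0-fold (0.31 log units) apart, within the scatter of two such steps. This does not show that the step is larger on the core of compound 3, that its size is fixed, or that it would hold on any further core, and the two pairs give no reason for the lower numbers.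

The compounds shown leave open what other groups on the same saturated chain carbon would do, such as morpholin-4-yl, a dimethylamino group or a piperazine without the methyl group, and whether a shorter or longer chain in place of the propyl chain would keep the step. They also leave open whether the step seen in this assay would appear on a core carrying neither of the two aryl groups present here.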